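Anilide halogen swap at the cytotoxicity ceiling

The source may report more compounds than this note shows. Statements on the series, on what has been measured and on what is new or still open speak of the compounds shown alone.

Working notes on a small set built on one shared core. Compound 1 `O=C(Nc1ccc(Cl)cc1)c1c(NCCO)cc(-c2cccc(Br)c2)oc1=O` in an ADME assay on Huh-7 cells (Homo sapiens) for cytotoxicity, with a stated time of 3 days (a higher number here means that more compound is tolerated, a lower number that less compound is tolerated), gives 17000 nM. Compound 2 `O=C(Nc1ccc(Br)cc1)c1c(NCCO)cc(-c2cccc(Br)c2)oc1=O` reaches only the limit of this assay, > 20000 nM. Compound 3 `O=C(Nc1ccc(Cl)cc1)c1c(NCCO)cc(-c2ccc(Br)cc2)oc1=O` likewise sits at the limit, > 20000 nM. Compound 3 therefore stands at the top edge of what the numbers shown can resolve, since the limit of > 20000 nM in this assay, at which 2 of the 3 values shown sit, caps it. The two measured steps both run into that ceiling: an at least 1.1-fold higher number from compound 1 to compound 2 (0.07 log units; that floor lies within the scatter), and an at least 1.1-fold higher number from compound 1 to compound 3 (0.07 log units; that floor lies within the scatter). Neither floor can be told from scatter.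

Compound 4 `O=C(Nc1ccc(Br)cc1)c1c(NCCO)cc(-c2ccc(Br)cc2)oc1=O` differs from compound 3 by bromo in place of chloro on an aromatic carbon. Among the measured compounds shown here, the single measured step bearing on this change is the one from compound 1 to compound 2, an at least 1.1-fold higher number from compound 1 to compound 2 (0.07 log units; that floor lies within the scatter), which only confirmed that tolerance did not fall. Nothing here points to a drop in tolerated concentration for bromo in place of chloro at this position, and compound 3 already sits at the limit. The step is therefore expected to be none beyond the scatter, a step that the limit leaves unreadable from compound 3 to compound 4, with compound 4 most likely reported again as a limit. Compound 4 is estimated at 25000 nM, within a range of 14000 nM to 50000 nM.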

Compound 4, half-maximal cytotoxic concentration: > 20000 nM
Compound 4 ended at the assay's limit; the forecaster's own chance of this, stated with the estimate: 85%; the middle value does not contradict the limit.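

No new step can be read for compound 4 against compound 2 or compound 3, because all three sit at one shared limit: the limit of > 20000 nM in this assay, at which 3 of the 4 values shown sit.

The compounds shown leave open how much compound is tolerated in this assay by compound 2, compound 3 and compound 4, and so whether chloro or bromo, or the bromine position on the phenyl group, matters there.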